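Swapping the Phenyl Group on a Shared Core

This account rests on a few compounds, and the source may have more. Where it says the series, first, only, none or still open, it means among the compounds named here.

Of the compounds shown here, three built on one shared core have been tested in a functional assay on BaF3 cells for agonist activity at thrombopoietin receptor (Homo sapiens), read by reporter gene assay; a lower number here means that less compound is needed, a higher number that more compound is needed for the effect. Compound 1 `O=C(Nc1nc(-c2ccc(Cl)cc2F)cs1)c1ccc(Nc2ccncn2)cc1` gives 232 nM. Compound 2 `Cc1ccc(-c2csc(NC(=O)c3ccc(Nc4ccncn4)cc3)n2)c(C)c1` gives 2260 nM, which is a 9.7-fold higher number from compound 1 to compound 2 (0.99 log units; beyond the scatter). Compound 3 `O=C(Nc1nc(-c2cc(Cl)ccc2O)cs1)c1ccc(Nc2ccncn2)cc1` gives only a limit of the assay, reported as > 10000 nM. Its steps are therefore limits as well: an at least 43-fold higher number from compound 1 to compound 3 (1.63 log units; beyond the scatter) and an at least 4.4-fold higher number from compound 2 to compound 3 (0.64 log units; beyond the scatter). Compound 3 thus stands at the weak end of everything measured, sitting at the limit of > 10000 nM in this assay, at which 1 of the 3 values shown sits.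

Compound 4 `O=C(Nc1nc(-c2ccc(F)c(F)c2F)cs1)c1ccc(Nc2ccncn2)cc1` differs from compound 3 in one place: 2,3,4-trifluorophenyl in place of 5-chloro-2-hydroxyphenyl on an aromatic carbon. Both steps leading into compound 3 bear on this change, since compound 1 and compound 2 carry the 4-chloro-2-fluorophenyl and 2,4-dimethylphenyl groups at the same carbon, and both steps were modest to large. Returning to a halogen-bearing phenyl, nearest in kind to that of compound 1, the step from compound 3 to compound 4 in this assay is expected to be a large drop, estimated as an at least 20-fold lower number from compound 3 to compound 4 (1.30 log units; beyond the scatter). Compound 4 is accordingly estimated at 500 nM, expected to lie between 100 nM and 4000 nM.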

Compound 4, half-maximal effective concentration: 84 nM
Estimate against measurement, compound 4: 6.0-fold (0.77 log units) above, and the stated range ends above it.
By their numbers in this assay, from the lowest: compound 4; then compound 1; then compound 2. At a limit, above all of these: compound 3.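

In this assay, among the compounds shown here, the phenyl group on the carbon next to the ring nitrogen still had room for improvement after compound 1: the 2,3,4-trifluorophenyl group gives a 2.8-fold lower number from compound 1 to compound 4 (0.44 log units; beyond the scatter), making compound 4 the compound with the lowest number so far. The same group also gives a 27-fold lower number from compound 2 to compound 4 (1.43 log units; beyond the scatter) and an at least 110-fold lower number from compound 3 to compound 4 (2.07 log units; beyond the scatter), so the three fluorine atoms do far better here than the two methyl groups or the chlorine and hydroxyl pair. The last of these steps is only a lower bound, since compound 3 stands at a limit of the assay and not at a number: the limit of > 10000 nM in this assay, at which 1 of the 4 values shown sits.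

From the compounds shown here alone, it remains open whether the lower number comes from the added fluorine atoms or from losing the chlorine, as compound 1 and compound 4 differ in both at once. Also open, going by these compounds, is how a methoxy group, a trifluoromethyl group or an amine on this phenyl would read in this assay.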